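Fluoro for Hydrogen on a Trimethoxyphenyl Urea

This account rests on a few compounds, and the source may have more. Where it says the series, first, only, none or still open, it means among the compounds named here.

Measured compounds:
Compound 1, `COc1cc(N(C)C(=O)N(C)c2cccc([N+](=O)[O-])c2)cc(OC)c1OC`, gives >= 125000 nM in a functional assay on ONS-76 cells (Homo sapiens) for cytotoxicity, read by MTT assay, with a stated time of 72 h; a higher number here means a weaker inhibitor, a lower number a stronger inhibitor.
Compound 2, `COc1cc(N(C)C(=O)N(C)c2ccccc2)cc(OC)c1OC`, gives "not determined" (no result reported) in this assay, that is, no reported result.

The value of compound 1 is a limit of the assay rather than a number, and it sits at the limit of >= 125000 nM in this assay, at which 1 of the 2 values shown sits. Within the data shown here, compound 2 therefore stands on no number at all in this assay; the only reading among the two is the limit of compound 1.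

The step to compound 3, `COc1cc(N(C)C(=O)N(C)c2cccc(F)c2)cc(OC)c1OC`, is fluoro in place of hydrogen on an aromatic carbon. Among the measured compounds shown here, since compound 2 has no value, no size of step can be computed. My expectation in this assay is a change no larger than the usual scatter in either direction, with the whole series looking weak.

For compound 3 I estimate a value around 100000 nM in this assay, expected to fall between 20000 nM and 300000 nM, with a fair chance that only a limit is reported.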

Compound 3, half-maximal inhibitory concentration: >= 125000 nM
Compound 3 gave a limit, no number; the forecaster's own chance of this, stated with the estimate: 60%; middle value at least 1.2-fold (0.09 log units) away from the limit.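

No step can be read from compound 1 to compound 3, since each gives only a limit and not a number: the limit of >= 125000 nM in this assay, at which 2 of the 3 values shown sit.

The compounds shown leave open whether phenyl to 3-fluorophenyl, going from compound 2 to compound 3, changes the result in this assay.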